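Swapping One Aryl Group on a Weakly Inhibiting Chloro Compound

The compounds below may be only part of what the source reports. "The series", "measured", "known", "first", "only" and "open" are said of these compounds alone.

In a functional assay on MCF7 cells (Homo sapiens) for antiproliferative activity, read by MTT assay, with a stated time of 48 h (on this read-out higher numbers stand for weaker inhibition and lower numbers for stronger inhibition), compound 1 (`COc1cccc(-c2nn(-c3ccccc3)cc2C(Nc2nc3ccccc3s2)c2c(O)ccc3ccccc23)c1`) gives 16900 nM as its half-maximal inhibitory concentration, while compound 2 (`COc1cccc(-c2nn(-c3ccccc3)cc2C(Nc2nc3ccc(Cl)cc3s2)c2c(O)ccc3ccccc23)c1`) gives 36000 nM as its own. Compound 2 therefore holds the higher of the two numbers, which means the weaker inhibition.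

Compound 3 (`O=[N+]([O-])c1ccc(-c2nn(-c3ccccc3)cc2C(Nc2nc3ccc(Cl)cc3s2)c2c(O)ccc3ccccc23)cc1`) keeps the chloro of compound 2 but carries 4-nitrophenyl in place of 3-methoxyphenyl on an aromatic carbon of a five-membered aromatic ring with 2 nitrogen (4-nitrophenyl in place of 3-methoxyphenyl on an aromatic carbon). For the measured compounds named here, no measurement yet covers a swap at this place. Going by the values given here, the only measured step, a 2.1-fold higher number from compound 1 to compound 2 (0.33 log units; beyond the scatter) for chloro in place of hydrogen on an aromatic carbon, is modest and concerns a different change, so it offers only a rough sense of scale.

In this assay a small step is therefore expected, with no shift beyond the scatter: a 1.2-fold lower number from compound 2 to compound 3 (0.08 log units; within the scatter) is the estimated change, and it remains quite uncertain. The estimate for compound 3 is 30000 nM with an expected range from 10000 nM to 80000 nM for now.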

Compound 3, half-maximal inhibitory concentration: 38600 nM
Beside the measured number, compound 3's estimate is 1.3-fold (0.11 log units) below it, within the range that was stated.
By their numbers in this assay, from the lowest: compound 1; then compounds 2 and 3 (each within the scatter of the next).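

In this assay, exchanging 3-methoxyphenyl for 4-nitrophenyl on this aromatic carbon of the five-membered ring gives a 1.1-fold higher number from compound 2 to compound 3 (0.03 log units; within the scatter), so the two compounds cannot be told apart on this read-out. For the compounds shown here, this is the first reading at this position, and it shows that, with the chloro kept in place, two quite different aryl groups give numbers within the scatter of each other, even though 4-nitrophenyl brings in nitrogen and a double bond outside the aromatic ring that 3-methoxyphenyl does not have. No supporting measurement is available to explain this result.

The compounds shown leave open how the same exchange would read on the core of compound 1, which has hydrogen where compound 2 has chloro, and this single pair cannot show whether the position would respond to a different kind of group, such as an amine or a carboxylic acid on the phenyl ring. It is also open whether any group here could bring stronger inhibition, since compound 2 gives 36000 nM and compound 3 gives 38600 nM, both at the weak end of the numbers shown.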